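A cyclohexylcarbamoyl group on the sulfonamide nitrogen of compound 1

A few compounds are considered here, and "the series" means these few. Any claim that something is new, unique, unknown or untested is made for them only; others in the source may bear on it.

Of the compounds shown here, three sharing a sulfonamide-bearing core have been tested in a functional assay on the whole organism (blood, strain albino) with Mus musculus as the target, with stated times of 6 days and 4 h, at a dose of 0.4 mmol/kg by the oral route; on this read-out higher numbers stand for more inhibition at the one dose given (going by the name of the read-out) and lower numbers for less inhibition. Compound 1 `C=CCNC(=S)NS(=O)(=O)c1ccc(-n2nc(C(=O)O)cc2C)cc1` gives -6%, the lowest of the three numbers. Compound 2 `Cc1cc(C)n(-c2ccc(S(=O)(=O)NC(=O)NNC(=N)N)cc2)n1` gives 3% in this assay, a number within the scatter of compound 1. Compound 3 `Cc1cc(C)n(-c2ccc(S(=O)(=O)NC(=O)NC3CCCCC3)cc2)n1` gives 10% in this assay, which lies beyond the scatter above compound 1. For the measured compounds named here, the one measured step between neighbours is a number 7 percentage points higher from compound 2 to compound 3 (within the scatter).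

Compound 4 `Cc1cc(C(=O)O)nn1-c1ccc(S(=O)(=O)NC(=O)NC2CCCCC2)cc1` differs from compound 1 in one place: a group of 9 heavy atoms (7 carbon, 1 nitrogen, 1 oxygen; one six-membered non-aromatic ring of carbon only) in place of a group of 6 heavy atoms (4 carbon, 1 nitrogen, 1 sulfur; no ring), on a sulfonamide nitrogen. The group that enters compound 4 is the same cyclohexylcarbamoyl group that compound 3 carries on its sulfonamide nitrogen, so the measured step from compound 2 to compound 3 is the one that bears on this change, and it was small. Compound 1 and compound 4 both keep the carboxylic acid on the core, whereas compound 3 does not, so the comparison is not exact. The step expected in this assay is therefore small, and in the upward direction if any: a number 9 percentage points higher from compound 1 to compound 4 (within the scatter). Compound 4 is estimated to give 3% in this assay, within a range from -9% to 15%.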

Compound 4, a percentage reported as inhibition, in the whole organism at one dose (the size of the read-out at that dose, not a potency): 1%
Beside the measured number, compound 4's estimate is 2 percentage points above it, and the stated range covers the measured number.
By their numbers in this assay, from the lowest: compounds 1, 4, 2 and 3 (each within the scatter of the next, the first and the last beyond it).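

In this assay, putting cyclohexylcarbamoyl on the sulfonamide nitrogen in place of the ring-free group of compound 1 gives a number 7 percentage points higher from compound 1 to compound 4 (within the scatter), so with carboxy kept on the core, this exchange cannot be told from repeat scatter. Compound 4 also opens a second place to comparison: with cyclohexylcarbamoyl held fixed, carboxy in place of methyl on an aromatic carbon gives a number 9 percentage points lower from compound 3 to compound 4 (within the scatter), and this change too stays inside the scatter, as does every other single-place step among the four compounds. No measurement at hand offers a reason for these numbers.

The compounds shown leave open whether any other group on the sulfonamide nitrogen, such as a phenylcarbamoyl group or a carbamoyl group bearing a longer carbon chain, would give a step beyond the scatter, and whether an ester, an amide or an amine in place of carboxy on the aromatic carbon would do so. They also leave open how these compounds would compare at any other oral dose, since this read-out gives the inhibition at a single dose and not a potency.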